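A few compounds are considered here, and "the series" means these few. Any claim that something is new, unique, unknown or untested is made for them only; others in the source may bear on it.

Measured compounds, values in an assay on HEK293 cells for positive allosteric modulation of metabotropic glutamate receptor 2 (Rattus norvegicus), read by thallium flux; on this read-out lower numbers stand for an effect already at smaller amounts and higher numbers for an effect only at larger amounts of compound:
compound 1, `Cn1sc2cc(OCc3cccc(-c4ccc(Cl)c(C(=O)O)c4)c3)ccc2c1=O`: 640 nM
compound 2, `COc1ccc(C(=O)O)cc1-c1cccc(COc2ccc3c(c2)CN(C2CCCC2)C3=O)c1`: 80 nM
compound 3, `CC(C)CCn1sc2cc(OCc3cccc(-c4ccc(Cl)c(C(=O)O)c4)c3)ccc2c1=O`: 650 nM

Compound 2 gives the lowest of the three numbers; the values of compound 1 and compound 3 both lie above it, beyond the scatter. Compound 4, `Cc1ccc(C(=O)O)cc1-c1cccc(COc2ccc3c(c2)CN(C2CCCC2)C3=O)c1`, differs from compound 2 by methyl in place of methoxy on an aromatic carbon. For the measured compounds named here, the only measured single step, a 1.0-fold higher number from compound 1 to compound 3 (0.01 log units; within the scatter), sits on the other core at a saturated chain carbon and says nothing about an exchange on an aromatic carbon; no measured pair tests the methoxy-to-methyl change. The step is therefore expected to stay close to the scatter, a 1.5-fold higher number from compound 2 to compound 4 (0.18 log units; within the scatter), with no direction favoured. In this assay compound 4 is expected at 120 nM, estimated range 40 nM to 400 nM.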

Compound 4, half-maximal effective concentration: 110 nM
For compound 4 the middle estimate is 1.1-fold (0.04 log units) above the measured one; the measured number falls inside the stated range.
By their numbers in this assay, from the lowest: compounds 2 and 4 (each within the scatter of the next); then compounds 1 and 3 (each within the scatter of the next).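

On the ring carbon ortho to a large group and para to a carboxy group, methyl in place of methoxy gives a 1.4-fold higher number from compound 2 to compound 4 (0.14 log units; within the scatter) in this assay. This first measured exchange on an aromatic carbon shows that the position accepts the loss of one heavy atom and the one hydrogen-bond acceptor without a step beyond the scatter. No supporting data bear on why the two groups read alike.

Open, as far as these compounds go, is how an amine or a longer chain such as ethoxy would read at this position. Also open, from the compounds shown here alone, is whether the same exchange stays within the scatter on the core of compound 1.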